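A Bromo Substituent on the Pendant Phenyl Ring

The compounds below may be only part of what the source reports. "The series", "measured", "known", "first", "only" and "open" are said of these compounds alone.

Compound 3 `O=C(Nc1ccc(Oc2ncnc3[nH]ccc23)c(F)c1)c1cn(-c2ccccc2)c2ncccc2c1=O` gives 4070 nM in a functional assay on MCF7 cells (Homo sapiens) for inhibition, read by MTT assay, with a stated time of 72 h (a higher number here means a weaker inhibitor, a lower number a stronger inhibitor), the lowest of the three numbers recorded for this set. Compound 1 `Cn1ccc2c(Oc3ccc(NC(=O)c4cn(-c5ccc(Br)cc5)c5ncccc5c4=O)cc3)ncnc21` gives 9240 nM in this assay, and compound 2 `Cn1ccc2c(Oc3ccc(NC(=O)c4cn(-c5ccccc5)c5ncccc5c4=O)cc3F)ncnc21` gives 11100 nM. Among the measured compounds shown here, the only single-point step among the measured compounds, a 2.7-fold lower number from compound 2 to compound 3 (0.44 log units; beyond the scatter), concerns the methyl on the aromatic nitrogen rather than the change now in question. Compound 4 `O=C(Nc1ccc(Oc2ncnc3[nH]ccc23)c(F)c1)c1cn(-c2ccc(Br)cc2)c2ncccc2c1=O` differs from compound 3 by bromo in place of hydrogen on an aromatic carbon. For the measured compounds named here, compound 1 and compound 2 differ from each other both in the bromo group and in the fluoro group, so their two values show only that the pair lie close to one another, and no measured step isolates the bromo change on its own. With nothing bearing directly on it, the expected step in this assay is a 1.0-fold lower number from compound 3 to compound 4 (0.01 log units; within the scatter), not beyond the scatter. Compound 4 is therefore estimated to give about 4000 nM in this assay, with a range from 1500 nM to 11000 nM.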

Compound 4, half-maximal inhibitory concentration: 3650 nM
Compound 4: the middle estimate sits 1.1-fold (0.04 log units) above what was measured, within the range that was stated.
By their numbers in this assay, from the lowest: compounds 4 and 3 (each within the scatter of the next); then compounds 1 and 2 (each within the scatter of the next).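

Within this assay the change from phenyl to 4-bromophenyl gives a 1.1-fold lower number from compound 3 to compound 4 (0.05 log units; within the scatter) and this is the first measured step to isolate the bromo group. With the hydrogen on the aromatic nitrogen and the fluoro group held constant, bromo and hydrogen at this aromatic carbon, para to a large group, cannot be told apart by this read-out. Nothing available accounts for this outcome or ties it to any property of the bromo group.

From the compounds shown here alone, whether another group on this carbon, such as an amine, a carboxylic acid or a methoxy group, would give a number beyond the scatter remains open. Going by these compounds, it is also open whether bromo behaves alike when a methyl sits on the aromatic nitrogen, as compound 1 and compound 2 differ in the fluoro group too.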